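From Benzimidazolylsulfanyl to Isoquinolinyloxy in Jurkat Cells

This account rests on a few compounds, and the source may have more. Where it says the series, first, only, none or still open, it means among the compounds named here.

Two compounds share a core built from a naphthyloxyacetyl group, a valine unit and an aspartate-derived ketone, and differ only in the group attached to the saturated chain carbon bound to the carbonyl carbon. Compound 1 `CC(C)[C@H](NC(=O)COc1cccc2ccccc12)C(=O)N[C@@H](CC(=O)O)C(=O)CSc1nc(-c2ccccc2)c(-c2ccccc2)o1` carries a diphenyloxazolylsulfanyl group there. In a functional assay on Jurkat cells (Homo sapiens) for inhibition (on this read-out lower numbers stand for stronger inhibition and higher numbers for weaker inhibition), compound 1 gives > 200000 nM, which is a limit of the assay rather than a number. Compound 2 `CC(C)[C@H](NC(=O)COc1cccc2ccccc12)C(=O)N[C@@H](CC(=O)O)C(=O)CSc1nc2ccccc2[nH]1` carries a benzimidazolylsulfanyl group in the same place. In this assay compound 2 also gives > 200000 nM, again a limit and not a number. So compound 2 stands at the limit of > 200000 nM in this assay, at which 2 of the 2 values shown sit, and there is no measured step in this set to lean on.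

Compound 3 `CC(C)[C@H](NC(=O)COc1cccc2ccccc12)C(=O)N[C@@H](CC(=O)O)C(=O)COc1cc2ccccc2cn1` differs from compound 2 in one place: (isoquinolin-3-yl)oxy in place of (1H-benzimidazol-2-yl)sulfanyl on a saturated chain carbon bound to a carbonyl carbon. No size or direction of change can be read from two limits, so any expectation is weak. The expected step from compound 2 to compound 3 is a number no higher from compound 2 to compound 3 (the limit leaves the size open). Compound 3 is estimated at 200000 nM, within a range from 50000 nM to 400000 nM, with a substantial chance of another limit.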

Compound 3, half-maximal inhibitory concentration: > 200000 nM
Compound 3 was reported as a limit; the forecaster's own chance of this, stated with the estimate: 65%; the middle value lies on the limit itself.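

In this assay compound 3 gives > 200000 nM, a limit of the assay and not a number. For the compounds shown here, compound 2 also sits at a limit, so no step between compound 2 and compound 3 can be read: the limit of > 200000 nM in this assay, at which 3 of the 3 values shown sit. The compounds shown leave open how strongly any of them inhibits, and whether (isoquinolin-3-yl)oxy in place of (1H-benzimidazol-2-yl)sulfanyl changes the read-out at all.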